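The compounds below may be only part of what the source reports. "The series", "measured", "known", "first", "only" and "open" are said of these compounds alone.

Compound 1 `COc1ccc(-c2cc(CN(c3nc4ccc(F)cc4s3)c3nc4ccc(OC)cc4s3)on2)cc1` and compound 2 `COc1ccc2nc(N(Cc3cc(-c4ccc(Br)cc4)no3)c3nc4ccc(F)cc4s3)sc2c1` share one core, while compound 3 `COc1ccc(-c2cc(CN(c3ncccn3)c3nc4ccccc4s3)on2)cc1` and compound 4 `Brc1ccc(-c2cc(CN(c3ncccn3)c3nc4ccccc4s3)on2)cc1` share another; the difference between the two cores is not broken down here. In a functional assay on COLO 205 cells (Homo sapiens) for antiproliferative activity, read by MTT assay (on this read-out higher numbers stand for weaker inhibition and lower numbers for stronger inhibition), compound 1 gives 11400 nM, compound 2 gives 7000 nM and compound 3 gives 5040 nM. For the measured compounds named here, the single counted change within the first pair, (bromo in place of methoxy on an aromatic carbon), produced a 1.6-fold lower number from compound 1 to compound 2 (0.21 log units; within the scatter). The same change appears once more, between compound 3 and compound 4, as bromo in place of methoxy on an aromatic carbon; the two place descriptions agree word for word, so this is the same kind of change carried onto the other core. Going by the values given here, the step from compound 3 to compound 4 in this assay is expected to be a 1.4-fold lower number from compound 3 to compound 4 (0.16 log units; within the scatter), set beside the earlier step, because a 1.6-fold lower number from compound 1 to compound 2 (0.21 log units; within the scatter) stayed within the scatter and no other measured pair in the set bears on this change. Among the compounds with values here, compound 4 is therefore estimated at 3500 nM, with a range from 1500 nM to 9000 nM reflecting that the only precedent rests on a single pair.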

Compound 4, half-maximal inhibitory concentration: 8820 nM
Estimate against measurement, compound 4: 2.5-fold (0.40 log units) below, within the range that was stated.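

In this assay, 4-bromophenyl in place of 4-methoxyphenyl on the core of compound 3 gives a 1.8-fold higher number from compound 3 to compound 4 (0.24 log units; within the scatter), and the gap between this step and the one on the core of compound 1 exceeds the scatter expected of two such steps: the same change on two cores in this assay, a 1.6-fold lower number (0.21 log units; within the scatter) from compound 1 to compound 2 and a 1.8-fold higher number (0.24 log units; within the scatter) from compound 3 to compound 4, 2.9-fold (0.45 log units) apart, beyond the scatter of two such steps. The change therefore does not carry from one core to the other as a fixed step in this assay, and the earlier step on the core of compound 1 is a poor guide to the size or direction of the step on the core of compound 3. Each step taken alone still lies within the scatter, so neither core shows a clear effect of the change by itself, and with a single pair per core the data cannot tell which of the differences between the cores accounts for the gap.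

Still open, as far as these compounds go, is how an amine or a carboxylic acid in this place would behave on either core. Also open, from the compounds shown here alone, is whether the same change on a third core would follow compound 1 to compound 2 or compound 3 to compound 4.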